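From Methylphenyl to Bromophenyl on the Triazole

This account rests on a few compounds, and the source may have more. Where it says the series, first, only, none or still open, it means among the compounds named here.

Compound 1 `Cc1cccc(-n2nncc2CN2C(=O)C3(C(C#N)=C(N)Oc4c3c3nc5ccccc5nc3c3ccccc43)c3ccccc32)c1` has been tested in an ADME assay on L02 cells (Homo sapiens) for antiproliferative activity, read by MTT assay, with a stated time of 48 h; a lower number here means a stronger inhibitor, a higher number a weaker inhibitor. In this assay compound 1 gives > 50000 nM, which is a limit of the assay rather than a measured number. Compound 2 `N#CC1=C(N)Oc2c(c3nc4ccccc4nc3c3ccccc23)C12C(=O)N(Cc1cnnn1-c1cccc(Cl)c1)c1ccccc12` differs from it in one place, and in this assay compound 2 gives 35200 nM. The step of an at least 1.4-fold lower number from compound 1 to compound 2 (0.15 log units; that floor lies within the scatter) is known only as a floor that lies within the scatter because the limit of > 50000 nM in this assay, at which 1 of the 2 values shown sits, fixes the starting point at the limit.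

Compound 3 `N#CC1=C(N)Oc2c(c3nc4ccccc4nc3c3ccccc23)C12C(=O)N(Cc1cnnn1-c1ccc(Br)cc1)c1ccccc12` is still to be measured. Its change from compound 1 is 4-bromophenyl in place of 3-methylphenyl on an aromatic nitrogen. For the measured compounds named here, the only measured step that bears on it, an at least 1.4-fold lower number from compound 1 to compound 2 (0.15 log units; that floor lies within the scatter), is a comparable exchange of one small group and gave no move beyond the scatter. A step of an at least 1.2-fold lower number from compound 1 to compound 3 (0.09 log units; that floor lies within the scatter) is therefore expected, with a fair chance that only a limit is reported again. For compound 3 the estimate in this assay is 40000 nM, within 15000 nM to 100000 nM.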

Compound 3, half-maximal inhibitory concentration: > 50000 nM
Compound 3 gave a limit, no number (the forecaster's own chance of this, stated with the estimate: 40%); at least 1.2-fold (0.09 log units) between middle value and limit.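

In this assay compound 3 gives > 50000 nM, which is a limit of the assay and not a number. Exchanging 3-chlorophenyl for 4-bromophenyl on the aromatic nitrogen gives an at least 1.4-fold higher number from compound 2 to compound 3 (0.15 log units; that floor lies within the scatter), so this change is not shown to move the value beyond the usual scatter. The step between the methylphenyl and bromophenyl compounds cannot be read, and any difference between them stays hidden, because both stop at the same limit: the limit of > 50000 nM in this assay, at which 2 of the 3 values shown sit.

The compounds shown cannot separate the choice of ring substituent from its place on the ring, which a 3-bromophenyl or 4-chlorophenyl group would help to do. From the compounds shown here alone, it also remains open whether an amine or a carboxylic acid on this phenyl ring would give a value clearly below the limit.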